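Benzyloxy to 4-bromobutoxy in a brominated diaryl ether

The source may report more compounds than this note shows. Statements on the series, on what has been measured and on what is new or still open speak of the compounds shown alone.

Measured compounds:
compound 1 `Brc1ccc(Oc2cc(Br)cc(Br)c2OCc2ccccc2)c(Br)c1`: 29 ug/mL
compound 2 `C#CCOc1c(Br)cc(Br)cc1Oc1ccc(Br)cc1Br`: 29.5 ug/mL
compound 3 `CN1CCN(CCCCCOc2c(Br)cc(Br)cc2Oc2ccc(Br)cc2Br)CC1`: 49.1 ug/mL

In a functional assay on U-937 cells (Homo sapiens) for cytotoxicity, read by MTT assay, with a stated time of 24 h (on this read-out lower numbers stand for stronger inhibition and higher numbers for weaker inhibition), compound 1 gives 29 ug/mL, the smallest of the three numbers, yet compound 2 and compound 3 are not separated from it beyond the scatter. Compound 4 `BrCCCCOc1c(Br)cc(Br)cc1Oc1ccc(Br)cc1Br` differs from compound 1 in one place: 3-bromopropyl in place of phenyl on a saturated chain carbon bound to an oxygen on an aromatic ring. Within the data shown here, the only measured step at this place, a 1.0-fold higher number from compound 1 to compound 2 (0.01 log units; within the scatter), left the number essentially unchanged; no step with a bromoalkyl group is available. Compound 4 is therefore expected to stay within the scatter of compound 1, a step of a 1.1-fold higher number from compound 1 to compound 4 (0.04 log units; within the scatter), and its estimated value is 32 ug/mL, with a range from 18 ug/mL to 60 ug/mL.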

Compound 4, half-maximal inhibitory concentration: 29 ug/mL
The estimate for compound 4 lay 1.1-fold (0.04 log units) above the measured number; the measured number falls inside the stated range.
By their numbers in this assay, from the lowest: compounds 1, 4, 2 and 3 (each within the scatter of the next).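

In this assay, the open 4-bromobutoxy chain takes the place of benzyloxy with no separable effect (no change at the digits printed from compound 1 to compound 4 (within the scatter)), so a ring on this chain is not required to keep the number. The 3-bromopropyl group is also within the scatter of ethynyl (a 1.0-fold lower number from compound 2 to compound 4 (0.01 log units; within the scatter)), and bromo within that of (4-methylpiperazin-1-yl)methyl at the chain end (a 1.7-fold lower number from compound 3 to compound 4 (0.23 log units; within the scatter)). No measurement here bears on the reason for these results. Going by these compounds, whether a carboxylic acid or a primary amine at the chain end, or a longer chain, would move the number beyond the scatter remains open.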